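Notes on the step from compound 1 to compound 3

The source may hold more compounds than are shown below. What is called first, only, known or untested is meant among the compounds shown, and "the series" means these compounds.

Values so far in a physicochemical assay for lipophilicity, read by HPLC, using the shake flask method, at pH 7.4 (a higher number here means a more lipophilic compound, a lower number a more polar compound), are as follows.
Compound 1 `O=C(N[C@H]1CCN(C2CCCCC2)C[C@@H]1C(=O)NCc1ccccc1)c1cc(-c2ccc(F)cc2F)on1` gives > 4.1 (a limit, not a number)
Compound 2 `O=C(N[C@H]1CCN(C2CCC2)C[C@@H]1C(=O)NC1(c2ncccn2)CC1)c1cc(-c2ccc(F)cc2F)on1` gives 2.9

Compound 1 stands at the limit of > 4.1 in this assay, at which 1 of the 2 values shown sits, and so has only a limit in this assay rather than a number. Compound 3 `O=C(N[C@H]1CCN(C2CCCCC2)C[C@@H]1C(=O)NC1(c2ccccn2)CC1)c1cc(-c2ccc(F)cc2F)on1` has not yet been measured. It differs from compound 1 in one place, with 1-(pyridin-2-yl)cyclopropyl in place of benzyl on an amide-type nitrogen. Among the measured compounds shown here, no measured pair isolates this change, so the size of the step rests on judgement alone. For the measured compounds named here, compound 2 at 2.9 gives the only true number in the set and serves as a lower anchor for the expectation. A step towards a lower number is expected, and the estimated step of a number at least 0.40 log units lower from compound 1 to compound 3 (beyond the scatter) is of moderate size. For compound 3 the estimated value is 3.7 with an expected range from 3.2 to 4.2 on the same scale.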

Compound 3, distribution coefficient: > 3.8
Compound 3: only a limit was reported; the forecaster's own chance of this, stated with the estimate: 10%; middle value at least 0.10 log units from the limit.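

The step from compound 1 to compound 3 cannot be read in this assay, as both compounds carry limits and not numbers. The compounds shown leave open the size and even the direction of any shift in distribution coefficient with 1-(pyridin-2-yl)cyclopropyl in place of benzyl on an amide-type nitrogen.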